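A Fluoro Added to Compound 2

The source may hold more compounds than are shown below. What is called first, only, known or untested is meant among the compounds shown, and "the series" means these compounds.

Measured in an ADME assay on BHK-21 cells (Mesocricetus auratus) for cytotoxicity, read by MTT assay, with a stated time of 72 h; a lower number here means that less compound is tolerated, a higher number that more compound is tolerated:
- compound 1 `NS(=O)(=O)c1ccc(N2N=C(c3ccc(OCc4ccccc4)cc3)CC2c2ccccc2)cc1`: 80000 nM
- compound 2 `NS(=O)(=O)c1ccc(N2N=C(c3ccc(Oc4ccccc4)cc3)CC2c2ccccc2)cc1`: 11000 nM
- compound 3 `Cc1ccc(C2CC(c3ccc(OCc4ccccc4)cc3)=NN2c2ccc(S(N)(=O)=O)cc2)cc1`: 32000 nM

Of these three, compound 2 has the lowest number, so it is the least tolerated so far. The next compound, compound 4 `NS(=O)(=O)c1ccc(N2N=C(c3ccc(Oc4ccccc4)cc3)CC2c2cccc(F)c2)cc1`, differs from it by fluoro in place of hydrogen on an aromatic carbon, which is fluoro in place of hydrogen on an aromatic carbon.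

The nearest guide is a 2.5-fold lower number from compound 1 to compound 3 (0.40 log units; beyond the scatter), where methyl replaces hydrogen on an aromatic carbon. That step is modest, and it involves a different group on a different parent. The other measured step, a 7.3-fold lower number from compound 1 to compound 2 (0.86 log units; beyond the scatter), changes another part of the molecule and says little about this swap. For the measured compounds named here, no measured pair shows what fluoro itself does. A small step is therefore expected, perhaps slightly downward and possibly no larger than the scatter. The estimated step is a 1.2-fold lower number from compound 2 to compound 4 (0.09 log units; within the scatter). For compound 4 the expected value is 9000 nM, with an estimated range of 4000 nM to 22000 nM.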

Compound 4, half-maximal cytotoxic concentration: 10000 nM
The estimate for compound 4 lay 1.1-fold (0.05 log units) below the measured number; the measured number falls inside the stated range.
By their numbers in this assay, from the lowest: compounds 4 and 2 (each within the scatter of the next); then compound 3; then compound 1.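

In this assay, exchanging phenyl for 3-fluorophenyl gives a 1.1-fold lower number from compound 2 to compound 4 (0.04 log units; within the scatter). Compound 2 and compound 4 therefore cannot be told apart here, which shows that a fluoro at this place, meta to a large group, leaves the number within the usual scatter on this parent. Nothing available explains this result.

Going by these compounds, it remains open whether a larger group on the same carbon, such as trifluoromethyl or an amine, would also leave the number within the scatter, and what fluoro would do on the other carbons of this ring. It is also unknown whether the same swap would give a similar result on compound 1, which carries the benzyl group on the oxygen in place of the phenyl of compound 2.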